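This account rests on a few compounds, and the source may have more. Where it says the series, first, only, none or still open, it means among the compounds named here.

Measured so far:
compound 1 `COc1ccc(-c2cc(C(=O)N3CCC4(CC3)CC(=O)c3nn(C(C)(C)C)cc3O4)c3ccccc3n2)cc1`: 3740 nM
compound 2 `CC(C)(C)n1cc2c(n1)C(=O)CC1(CCN(C(=O)c3cc(-c4ccc(N)cc4)nc4ccccc34)CC1)O2`: 970 nM

In a functional assay on A549 cells (Homo sapiens) for inhibition, read by MTT assay, with a stated time of 72 h (on this read-out lower numbers stand for stronger inhibition and higher numbers for weaker inhibition), compound 1 gives 3740 nM and compound 2 gives 970 nM. For the measured compounds named here, compound 2 holds the lowest of the two numbers; the only measured step is a 3.9-fold lower number from compound 1 to compound 2 (0.59 log units; beyond the scatter), with amino in place of methoxy on an aromatic carbon.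

Compound 3 `CC(C)Oc1cc(C(=O)N2CCC3(CC2)CC(=O)c2nn(C(C)(C)C)cc2O3)c2ccccc2n1` differs from compound 2 by isopropoxy in place of 4-aminophenyl on an aromatic carbon. Going by the values given here, no measured step removes the 4-aminophenyl itself; a 3.9-fold lower number from compound 1 to compound 2 (0.59 log units; beyond the scatter) shows only that the group on that ring shifts the number beyond the scatter. Removing the ring is expected to raise the number in this assay. For compound 3 the expected step is a 5.2-fold higher number from compound 2 to compound 3 (0.71 log units; beyond the scatter). Compound 3 is estimated at 5000 nM, range 1500 nM to 20000 nM.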

Compound 3, half-maximal inhibitory concentration: > 10000 nM
Compound 3: no number, only a limit (the forecaster's own chance of this, stated with the estimate: 10%); middle value at least 2.0-fold (0.30 log units) from the limit.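

Compound 3 carries only a limit, > 10000 nM in this assay, not a number: the limit of > 10000 nM in this assay, at which 1 of the 3 values shown sits.

Isopropoxy in place of 4-aminophenyl gives an at least 10-fold higher number from compound 2 to compound 3 (1.01 log units; beyond the scatter), and isopropoxy in place of 4-methoxyphenyl gives an at least 2.6-fold higher number from compound 1 to compound 3 (0.42 log units; beyond the scatter). The earlier step changed only a group on the phenyl ring, whereas these steps show that replacing the whole aryl group at this carbon next to the ring nitrogen costs activity, from either aryl compound.

Going by these compounds, the true size of both steps stays open beyond these bounds. Also open, on these data alone, is whether an unsubstituted phenyl or a pyridine ring at this carbon would hold the activity of compound 2.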